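Swapping Fluoro for Methyl on a Fused Ring

The compounds below may be only part of what the source reports. "The series", "measured", "known", "first", "only" and "open" are said of these compounds alone.

Three compounds share one core, which carries an ethyl group, an aniline-type arm and a thioether arm that ends in different groups. Compound 1 `CCn1c(CNc2ccccc2)nnc1SCC(=O)Nc1ccc(C(=O)OC)cc1` ends in an ester-bearing amide, and in an assay on isolated protein for inhibition of long-chain fatty acid transport protein 1 (Mus musculus) (on this read-out higher numbers stand for weaker inhibition and lower numbers for stronger inhibition), compound 1 has the entry "not determined" (no result reported). Compound 2 `CCn1c(CNc2ccccc2)nnc1SCc1nc2cc(F)ccc2o1` ends in a fused two-ring system and was tested in this assay, where compound 2 gives 7800 nM. For the measured compounds named here, on this read-out compound 2 holds the only number, so it stands alone, with nothing to compare it against.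

Compound 3 `CCn1c(CNc2ccccc2)nnc1SCc1nc2cc(C)ccc2o1` differs from compound 2 in one place: methyl in place of fluoro on an aromatic carbon. Both the group that leaves and the group that enters are small and neutral, as the counted difference shows. Going by the values given here, no step between measured compounds resembles this exchange, so there is nothing in the data to suggest a direction. The exchange is therefore expected to move potency little, if at all, beyond the usual scatter. The step from compound 2 to compound 3 is expected to be a 1.1-fold lower number from compound 2 to compound 3 (0.05 log units; within the scatter). Compound 3 is estimated at 7000 nM in this assay, within a range from 2500 nM to 20000 nM.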

Compound 3, half-maximal inhibitory concentration: > 10000 nM
Compound 3: only a limit was reported (the forecaster's own chance of this, stated with the estimate: 10%); middle value at least 1.4-fold (0.15 log units) from the limit.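

In this assay compound 3 gives > 10000 nM, which is a limit of the assay and not a number. Methyl in place of fluoro on this aromatic carbon is the first change at this position with a reading on both sides, and it gives an at least 1.2-fold higher number from compound 2 to compound 3 (0.10 log units; that floor lies within the scatter), so the result offers no sign that methyl brings a lower number than fluoro, yet it cannot show that methyl truly weakens inhibition, since that floor does not clear the usual scatter and the real gap could be small or large. The size of the step stays open because the reading stops at the top of what the assay reports: the limit of > 10000 nM in this assay, at which 1 of the 3 values shown sits.

The compounds shown leave open how a plain hydrogen, a chloro or a methoxy group on this same aromatic carbon would read in this assay, and a firm number for compound 3 would be needed before any of these could be ranked against methyl. With compound 1 entered as "not determined" (no result reported), they also leave open how its ester-bearing amide arm compares with the fused two-ring arm of compound 2.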